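Replacing the pyridinyl arm of compound 2 with an oxanyl arm

The source may report more compounds than this note shows. Statements on the series, on what has been measured and on what is new or still open speak of the compounds shown alone.

Measured compounds:
compound 1 `O=C(Nc1ccc(F)cc1)c1ccc(N(Cc2ccccc2)Cc2ccc(B(O)O)cn2)nc1`: 326 nM
compound 2 `O=C(Nc1ccc(F)cc1)c1ccc(N(Cc2ccccn2)Cc2ccc(B(O)O)cn2)nc1`: > 5000 nM

In a functional assay on RBL cells for antagonist activity at C-X-C chemokine receptor type 1 (Homo sapiens), read by fluorescence and calcium flux, with a stated time of 30 min (on this read-out higher numbers stand for weaker inhibition and lower numbers for stronger inhibition), compound 1 gives 326 nM. For compound 2 the read-out is only a limit of the assay, > 5000 nM, so no number is known for it (the limit of > 5000 nM in this assay, at which 1 of the 2 values shown sits). Between the two stands one measured step: an at least 15-fold higher number from compound 1 to compound 2 (1.18 log units; beyond the scatter). Compound 2 therefore sits at the weak end of what has been measured, with only a limit to mark it.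

Compound 3 `O=C(Nc1ccc(F)cc1)c1ccc(N(Cc2ccc(B(O)O)cn2)CC2CCOCC2)nc1` is not yet measured. It differs from compound 2 in one place: oxan-4-yl in place of pyridin-2-yl on a saturated chain carbon bound to a nitrogen on an aromatic ring. Among the compounds with values here, the only measured step that bears on this position is the one from compound 1 to compound 2, which was large, and it shows that this arm strongly affects the number in this assay. Within the data shown here, no step compares an oxan-4-yl arm with any other, so the direction for compound 3 is open. The step from compound 2 to compound 3 is expected to be an at least 1.6-fold lower number from compound 2 to compound 3 (0.22 log units; that floor lies within the scatter), with wide uncertainty. Compound 3 is estimated at 3000 nM, within 400 nM to 10000 nM, in this assay.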

Compound 3, half-maximal inhibitory concentration: > 5000 nM
Compound 3 ended at the assay's limit (the forecaster's own chance of this, stated with the estimate: 45%); middle value at least 1.6-fold (0.22 log units) from the limit.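

In this assay compound 3 also stops at a limit of the assay, > 5000 nM, and not at a number. Compared directly with the phenyl arm, the oxan-4-yl arm gives an at least 15-fold higher number from compound 1 to compound 3 (1.18 log units; beyond the scatter), so a non-aromatic ring with one hetero atom and an aromatic ring with one hetero atom have now both given a large step away from the value of compound 1 at this position. The step between compound 2 and compound 3 cannot be read, so pyridin-2-yl and oxan-4-yl cannot be ranked against each other, and all that can be said of the two arms is that they share one end of the range: the limit of > 5000 nM in this assay, at which 2 of the 3 values shown sit.

Among the three arms shown, only the phenyl arm of compound 1 gives a number, so it stays open how much change this position tolerates and how far the two limited compounds really lie from it. A cyclohexyl arm would separate the loss of the aromatic ring from the presence of the ring oxygen, and a phenyl arm carrying a fluoro group would show whether any substitution on that ring keeps a readable value.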